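The compounds below may be only part of what the source reports. "The series", "measured", "known", "first", "only" and "open" are said of these compounds alone.

In a physicochemical assay for solubility, at pH 7.4 (on this read-out higher numbers stand for higher solubility and lower numbers for lower solubility), compound 2 (`Cc1cc(NC(=O)Nc2ccc(N)cc2)c2ccccc2n1`) reads 18500 nM and stands highest of the two numbers, with compound 1 (`CSc1ccc(NC(=O)Nc2cc(C)nc3ccccc23)cc1`) at 1300 nM on the same read-out. Compound 3 (`Cc1cc(NC(=O)Nc2ccc(Cl)cc2)c2ccccc2n1`) carries chloro in place of amino on an aromatic carbon, para to a large group (chloro in place of amino on an aromatic carbon). For the measured compounds named here, only one measured step bears on this, amino in place of methylsulfanyl. With a 14-fold higher number from compound 1 to compound 2 (1.15 log units; beyond the scatter) as the guide, large and beyond the scatter, a similarly large downward step is expected in this assay for compound 3. The estimate means a 12-fold lower number from compound 2 to compound 3 (1.09 log units; beyond the scatter) as the expected change. Compound 3 is expected at 1500 nM within an estimated range of 400 nM to 6000 nM on this read-out.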

Compound 3, solubility: 1400 nM
Compound 3: the middle estimate sits 1.1-fold (0.03 log units) above what was measured; measured number inside the range.
By their numbers in this assay, from the lowest: compounds 1 and 3 (each within the scatter of the next); then compound 2.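

In this assay, the position para to a large group now has a second replacement for amino, and the change to chloro also gives a large step (a 13-fold lower number from compound 2 to compound 3 (1.12 log units; beyond the scatter)). Chloro and methylsulfanyl read alike there (a 1.1-fold higher number from compound 1 to compound 3 (0.03 log units; within the scatter)), so among these three compounds amino alone stands apart. Nothing given here accounts for this. The compounds shown leave open whether a dimethylamino group, a carboxylic acid or a longer chain at this position would read with amino or with chloro, and whether amino would stand apart on another core.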